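Thiocarbamate amides: cytotoxicity on moving to a dimethoxyphenyl amide

A few compounds are considered here, and "the series" means these few. Any claim that something is new, unique, unknown or untested is made for them only; others in the source may bear on it.

Measured so far in an ADME assay on MT4 cells (Homo sapiens) for cytotoxicity, read by MTT assay; a lower number here means that less compound is tolerated, a higher number that more compound is tolerated:
- compound 1, `O=C1c2ccccc2C(=O)N1CCOC(=S)N(C(=O)c1ccc(C(F)(F)F)cc1)c1ccc(Cl)cc1`, gives 10000 nM.
- compound 2, `O=C1c2ccccc2C(=O)N1CCOC(=S)N(C(=O)c1cccnc1Cl)c1ccc(Br)cc1`, gives only a limit of the assay, > 100000 nM.
- compound 3, `Cc1ccc(N(C(=O)c2ccccc2C)C(=S)OCCN2C(=O)c3ccccc3C2=O)cc1`, likewise gives only a limit of the assay, > 100000 nM.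

Going by the values given here, compound 1 stands apart as the one member with a number in this assay; the other two sit at the limit of > 100000 nM in this assay, at which 2 of the 3 values shown sit. Among the compounds with values here, compounds 2 and 3 differ from compound 1 in more than one place, so no single step between measured compounds can be read off.

Compound 4, `COc1cccc(OC)c1C(=O)N(C(=S)OCCN1C(=O)c2ccccc2C1=O)c1ccc(Cl)cc1`, is not yet measured in this assay. It differs from compound 1 in one place:

2,6-dimethoxyphenyl in place of 4-(trifluoromethyl)phenyl on a carbonyl carbon

Within the data shown here, with no measured step on this position, the size of the change is open. The expectation for compound 4 is a modest move toward more compound tolerated, a 3.0-fold higher number from compound 1 to compound 4 (0.48 log units; beyond the scatter), a step that may not exceed the scatter. Compound 4 is therefore estimated at 30000 nM in this assay, within 8000 nM to 150000 nM, with a real chance that only a limit is reported.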

Compound 4, half-maximal cytotoxic concentration: 69000 nM
Beside the measured number, compound 4's estimate is 2.3-fold (0.36 log units) below it; the measured number falls inside the stated range.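

In this assay, going by these compounds alone, the first readable step at this position is a 6.9-fold higher number from compound 1 to compound 4 (0.84 log units; beyond the scatter), with 2,6-dimethoxyphenyl in place of 4-(trifluoromethyl)phenyl on a carbonyl carbon. The group on this carbonyl can therefore shift the read-out on its own, with the rest of compound 1 unchanged, and both ends of the step are numbers rather than limits. Compounds 2 and 3 each give only a limit of the assay and add no step at this position: the limit of > 100000 nM in this assay, at which 2 of the 4 values shown sit.

A single step cannot separate the loss of the trifluoromethyl from the entry of the methoxy groups. Going by these compounds, how an amine or a carboxylic acid on this phenyl would read in this assay also stays open.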